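Moving an iodine around a ring in a thiourea series

A few compounds are considered here, and "the series" means these few. Any claim that something is new, unique, unknown or untested is made for them only; others in the source may bear on it.

The compounds here share one core, a thiourea carrying a substituted benzyl group on one nitrogen and, on the other, a branched chain that ends in a pivalate ester and a dimethylphenyl group. Compound 1 `COc1cc(CNC(=S)NCC(COC(=O)C(C)(C)C)Cc2ccc(C)c(C)c2)cc(Cl)c1O` bears chlorine on its benzyl ring, but in a functional assay on CHO cells for antagonist activity at transient receptor potential cation channel subfamily V member 1 (Rattus norvegicus) (on this read-out higher numbers stand for weaker inhibition and lower numbers for stronger inhibition), compound 1 is recorded as "not evaluated" (no result reported), so no number exists for it. Compound 2 `COc1cc(CNC(=S)NCC(COC(=O)C(C)(C)C)Cc2ccc(C)c(C)c2)cc(I)c1O` carries iodine in the same place, and in this assay compound 2 gives 121 nM. Going by the values given here, this is the only measured value, so compound 2 stands alone, with nothing to rank it against.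

Compound 3 `COc1cc(CNC(=S)NCC(COC(=O)C(C)(C)C)Cc2ccc(C)c(C)c2)c(I)cc1O` has the same atoms joined differently: 4-hydroxy-2-iodo-5-methoxyphenyl in place of 4-hydroxy-3-iodo-5-methoxyphenyl on a saturated chain carbon bound to an amide-type nitrogen. Among the compounds with values here, no measured pair shows what this kind of rearrangement does, so any expectation rests on compound 2 alone. The step from compound 2 to compound 3 is expected to weaken inhibition by a margin beyond the usual scatter, as a 5.0-fold higher number from compound 2 to compound 3 (0.70 log units; beyond the scatter). Compound 3 is therefore estimated at 600 nM, within a range from 150 nM to 3000 nM.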

Compound 3, inhibition constant: 23.1 nM
For compound 3 the middle estimate is 26-fold (1.41 log units) above the measured one; the whole stated range lies above it.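

In this assay, putting 4-hydroxy-2-iodo-5-methoxyphenyl in place of 4-hydroxy-3-iodo-5-methoxyphenyl gives a 5.2-fold lower number from compound 2 to compound 3 (0.72 log units; beyond the scatter), and a lower number here means stronger inhibition. The two compounds contain the same atoms and the same counts of hydrogen-bond donors and acceptors, so this pair shows that inhibition depends on how the groups are arranged on this ring, not merely on which atoms the compound contains. Nothing given here explains why this arrangement inhibits more strongly.

This is a single pair, so it sets no general rule for the series, and it cannot say whether the same rearrangement would help with a different atom or group in place of the iodine, such as bromine or a methyl group. It also leaves open whether the result would hold if the rest of the molecule changed, for example with a free alcohol in place of the pivalate ester or an unsubstituted phenyl in place of the dimethylphenyl group.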